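Para substituent swap on the phenyl ring of compound 2

A few compounds are considered here, and "the series" means these few. Any claim that something is new, unique, unknown or untested is made for them only; others in the source may bear on it.

Measured so far:
compound 1 `Cc1ccc2c(Cc3nn4cc(-c5ccc(Cl)cc5)nc4s3)coc2c1` 58.1%
compound 2 `Cc1ccc2c(Cc3nn4cc(-c5ccc(Br)cc5)nc4s3)coc2c1` 22.5%

Among the compounds with values here, compound 2 gives 22.5% in a functional assay on the whole organism (strain Wistar albino) for inhibition, with Rattus norvegicus as the target, read by paw edema, with a stated time of 5 h, at a dose of 100 mg/kg by the oral route (a lower number here means less inhibition, a higher number more inhibition at the dose given (going by the name of the read-out)), and stands lowest of the two measured numbers; compound 1 is the nearest and sits higher by the one measured step, a number 35.6 percentage points lower from compound 1 to compound 2 (beyond the scatter), which lies beyond the scatter.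

Compound 3 `Cc1ccc2c(Cc3nn4cc(-c5ccc([N+](=O)[O-])cc5)nc4s3)coc2c1` is not yet measured. It differs from compound 2 by nitro in place of bromo on an aromatic carbon. Within the data shown here, no measured step concerns a nitro group, so the only step on record, a number 35.6 percentage points lower from compound 1 to compound 2 (beyond the scatter), bears on this change only in showing that a single substituent change at this position can move the read-out by a large amount in either direction. Direction and size for the bromo to nitro change therefore cannot be read from the data; a step of either sign or none beyond the scatter remains possible.

As a working estimate, compound 3 is expected to give 40% in this assay, in the range 15% to 65%, which means an expected step of a number 17.5 percentage points higher from compound 2 to compound 3 (beyond the scatter).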

Compound 3, a percentage reported as inhibition, in the whole organism at one dose (the size of the read-out at that dose, not a potency): 49.8%
Beside the measured number, compound 3's estimate is 9.8 percentage points below it, within the range that was stated.
By their numbers in this assay, from the lowest: compound 2; then compounds 3 and 1 (each within the scatter of the next).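

In this assay, nitro in place of bromo gives a number 27.3 percentage points higher from compound 2 to compound 3 (beyond the scatter), so the low reading of compound 2 does not extend to every replacement of chloro at this place on the six-membered aromatic ring. Nitro in place of chloro gives a number 8.3 percentage points lower from compound 1 to compound 3 (within the scatter), so this read-out does not separate compound 1 from compound 3, although the two groups differ in their atoms and nitro carries hydrogen-bond acceptors; among the three compounds, compound 2 alone stands apart, with steps beyond the scatter to both others. Nothing available explains why bromo stands apart from chloro and nitro in this series.

Going by these compounds, whether an amine, a methoxy group or a carboxylic acid at this place would read with compound 2 or with compounds 1 and 3 remains open, as does whether the low reading belongs to bromo alone or would also appear with iodo. With one dose and one stated time, this assay also leaves open whether the gap between compound 2 and the other two reflects potency or would hold at other doses and times.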